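Volume of distribution in a pyridone-indole amide series

This account rests on a few compounds, and the source may have more. Where it says the series, first, only, none or still open, it means among the compounds named here.

Measured so far:
- compound 1 `CC(C)n1cc(-c2ccnc3[nH]c(C4CCN(CC(=O)N5CCCCC5)CC4)cc23)ccc1=O`: 8.1 L/kg
- compound 2 `CC(C)n1cc(-c2ccnc3[nH]c(C4CCN(CC(=O)N(C)C)CC4)cc23)cnc1=O`: 2.9 L/kg

In an ADME assay (Rattus norvegicus, strain Han-wistar) for pharmacokinetics, at a dose of 1.5 umol/kg by the intravenous route (a higher number here means that more of the compound sits outside the plasma, a lower number that more of the compound stays in the plasma), compound 2 stands lowest of the two numbers; compound 1 gives a number a good deal higher, and the gap lies beyond the scatter. Compound 3 `CC(C)n1cc(-c2ccnc3[nH]c(C4CCN(CC(=O)N(C)C)CC4)cc23)ccc1=O` is not yet measured. Relative to compound 2 the change is a group of 10 heavy atoms (8 carbon, 1 nitrogen, 1 oxygen; one six-membered aromatic ring with 1 hetero atom) in place of a group of 10 heavy atoms (7 carbon, 2 nitrogen, 1 oxygen; one six-membered aromatic ring with 2 hetero atoms), on an aromatic carbon.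

For the measured compounds named here, no step between measured compounds isolates this change, so the step of a 1.7-fold higher number from compound 2 to compound 3 (0.24 log units; within the scatter) is an expectation, upward, because compound 1 with the same entering ring gives 8.1 L/kg. For compound 3 the estimate is 5 L/kg, range 2.5 L/kg to 10 L/kg.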

Compound 3, volume of distribution: 5.9 L/kg
For compound 3 the middle estimate is 1.2-fold (0.07 log units) below the measured one, and the stated range covers the measured number.
By their numbers in this assay, from the lowest: compound 2; then compounds 3 and 1 (each within the scatter of the next).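

In this assay, the ring change on the aromatic carbon opposite the ring nitrogen now has a direct reading: a 2.0-fold higher number from compound 2 to compound 3 (0.31 log units; beyond the scatter), a modest step with the ring with 1 hetero atom entering in place of the ring with 2 hetero atoms. On the carbonyl carbon, dimethylamino in place of piperidin-1-yl gives a 1.4-fold lower number from compound 1 to compound 3 (0.14 log units; within the scatter), a step that stays within the scatter. No measurement at hand bears on why the ring change moves this number.

Going by these compounds, whether the ring step holds with piperidin-1-yl on the carbonyl carbon remains open, as compound 1 has no partner carrying the other ring. Also open, on these data alone, is how a carboxylic acid in place of the amide would read.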